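Amine swap on two cores: compound 4 awaits measurement

The compounds below may be only part of what the source reports. "The series", "measured", "known", "first", "only" and "open" are said of these compounds alone.

Compound 1 `COc1ccc2cc(C(=O)CCN(C)C)c(=O)oc2c1` carries a dimethylamino group on a saturated chain carbon, two bonds along the chain from a carbonyl carbon. In a functional assay on SH-SY5Y cells (Homo sapiens) for cytotoxicity, read by MTT assay, with stated times of 1 h and 24 h (a higher number here means that more compound is needed for the effect, a lower number that less compound is needed), compound 1 gives > 100000 nM, a limit of the assay. Compound 2 `COc1ccc2cc(C(=O)CCN3CCCC3)c(=O)oc2c1` differs from it by pyrrolidin-1-yl in place of dimethylamino on a saturated chain carbon, two bonds along the chain from a carbonyl carbon. In this assay compound 2 gives > 100000 nM, again a limit. The step that the two limits leave unreadable from compound 1 to compound 2 is thus unreadable. Compound 3 `CN(C)CCC(=O)c1cc2cc(Br)c(O)c(Br)c2oc1=O` has another core; how its core differs from that of compound 1 is not broken down here. In this assay compound 3 gives > 100000 nM, also a limit. Compound 4 `O=C(CCN1CCCC1)c1cc2cc(Br)c(O)c(Br)c2oc1=O` repeats the same change on the core of compound 3: pyrrolidin-1-yl in place of dimethylamino on a saturated chain carbon, two bonds along the chain from a carbonyl carbon. Because all three values sit at the limit (the limit of > 100000 nM in this assay, at which 3 of the 3 values shown sit), the step from compound 3 to compound 4 is expected to be small, a step that the limit leaves unreadable from compound 3 to compound 4. Compound 4 is expected at 150000 nM in this assay, between 60000 nM and 400000 nM, most likely reported again only as a limit.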

Compound 4, half-maximal effective concentration: 75100 nM
Estimate against measurement, compound 4: 2.0-fold (0.30 log units) above; low and high end bracket the measured number.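

In this assay the swap of dimethylamino for pyrrolidin-1-yl on the core of compound 3 gives an at least 1.3-fold lower number from compound 3 to compound 4 (0.12 log units; that floor lies within the scatter). This floor alone does not establish a real change on that core, although the true step may be larger. The matching step on the core of compound 1 cannot be read, so the change cannot be shown to carry over from one core to the other, because most values sit at a limit: the limit of > 100000 nM in this assay, at which 3 of the 4 values shown sit.

Still open, from the compounds shown here alone, is how a piperidin-1-yl or morpholin-4-yl group would read on the same chain. Going by these compounds, a longer chain carrying the amine is equally open on either core.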